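The source may report more compounds than this note shows. Statements on the series, on what has been measured and on what is new or still open speak of the compounds shown alone.

Compound 1 `COc1ccc(N(CC(=O)NCCC[Se]c2ccccc2)C(=O)c2ccccc2)cc1`: >= 100000 nM (a limit)
Compound 2 `COc1ccc(N(CC(=O)NCCC[Se]c2ccccc2)C(=O)CNC(=O)OC(C)(C)C)cc1`: >= 100000 nM (a limit)
Compound 3 `COc1ccc(N(CC(=O)NCCC[Te]c2ccccc2)C(=O)CCSC2=C(C)C(=O)c3ccccc3C2=O)cc1`: 4000 nM

In an ADME assay on cells (Fibroblast, Homo sapiens) for cytotoxicity, read by MTT assay, with a stated time of 24 h (on this read-out lower numbers stand for stronger inhibition and higher numbers for weaker inhibition), compound 1 gives >= 100000 nM, which is a limit of the assay and not a number. Compound 2 likewise gives only a limit. For the measured compounds named here, the one measured step is a step that the two limits leave unreadable from compound 1 to compound 2, so it offers no size to carry forward, and it concerns a group on a carbonyl carbon rather than the group changed here. Compound 3 does give a number, 4000 nM, but it differs from compound 1 in more than one place and so offers no clean comparison.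

Compound 4 `COc1ccc(N(CC(=O)NCCCSc2ccccc2)C(=O)c2ccccc2)cc1` keeps the core of compound 1 and changes a single group: a group of 7 heavy atoms (6 carbon, 1 sulfur; one six-membered aromatic ring of carbon only) in place of a group of 7 heavy atoms (6 carbon, 1 selenium; one six-membered aromatic ring of carbon only), on a saturated chain carbon, three bonds along the chain from an amide-type nitrogen. Phenylsulfanyl is the entering group, and no measured pair shows this exchange directly. Because the limit of >= 100000 nM in this assay, at which 2 of the 3 values shown sit, is where compound 1 sits, compound 4 is expected to stay in that same range, with no step beyond the scatter in this assay. The estimated change is a step that the limit leaves unreadable from compound 1 to compound 4. The assay may well report only a limit again for compound 4. For compound 4 the expected value is 120000 nM, with an estimated range of 50000 nM to 300000 nM.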

Compound 4, half-maximal inhibitory concentration in the Fibroblast assay: >= 100000 nM
Compound 4 was reported as a limit; the forecaster's own chance of this, stated with the estimate: 80%; the middle value is on the limit's open side.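

In the Fibroblast assay compound 4 gives >= 100000 nM which is a limit of the assay and not a number. For the compounds shown here, compound 1 also gives only a limit, so no step from compound 1 to compound 4 can be read: the limit of >= 100000 nM in the Fibroblast assay, at which 3 of the 4 values shown sit. The compounds shown leave open whether phenylsulfanyl in place of the selenium-bearing group changes this cytotoxicity result at all. In a physicochemical assay for lipophilicity, read by HPLC, measured as octanol-water partition (a higher number here means a more lipophilic compound, a lower number a more polar compound), compound 1 gives 3.1 and compound 4 gives 3.1.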